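This account rests on a few compounds, and the source may have more. Where it says the series, first, only, none or still open, it means among the compounds named here.

Going by the values given here, in an assay on HepG2 cells for agonist activity at nuclear receptor subfamily 1 group I member 3 (Homo sapiens), read by a luciferase reporter, with a stated time of 23 h (a higher number here means that more compound is needed for the effect, a lower number that less compound is needed), compound 1 `CC(C)(C)c1ccc(CO/N=C/c2c(-c3ccc4ccccc4c3)nc3occn23)cc1` gives 7900 nM, the highest of the three numbers measured so far. Among the compounds with values here, compound 2 `Clc1ccc(CO/N=C/c2c(-c3ccccc3)nc3sccn23)cc1Cl` gives 580 nM and compound 3 `COc1ccc(-c2nc3sccn3c2/C=N/OCc2ccc(Cl)c(Cl)c2)cc1` gives 490 nM; the only single-change step among the measured compounds, a 1.2-fold lower number from compound 2 to compound 3 (0.07 log units; within the scatter), concerns a different part of the molecule and is within the scatter. Compound 4 `Clc1ccc(CO/N=C/c2c(-c3ccc4ccccc4c3)nc3occn23)cc1` differs from compound 1 by chloro in place of tert-butyl on an aromatic carbon. Within the data shown here, no measured step covers this exact change. Compounds 2 and 3 do carry chloro groups on the corresponding ring and give far lower numbers than compound 1, but they also differ from it in the core and in the other aromatic group, so they offer only a loose hint. A moderate step to a lower number is therefore expected, a 2.6-fold lower number from compound 1 to compound 4 (0.42 log units; beyond the scatter), with wide uncertainty. Compound 4 is estimated at 3000 nM, within a range from 800 nM to 12000 nM.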

Compound 4, half-maximal effective concentration: 990 nM
The estimate for compound 4 lay 3.0-fold (0.48 log units) above the measured number; measured number inside the range.
By their numbers in this assay, from the lowest: compounds 3, 2 and 4 (each within the scatter of the next, the first and the last beyond it); then compound 1.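

In this assay, chloro in place of tert-butyl on this aromatic carbon, with the rest of the molecule unchanged, gives an 8.0-fold lower number from compound 1 to compound 4 (0.90 log units; beyond the scatter). Going by these compounds alone, this isolates the position for the first time and shows that the number responds to the group placed there, which compounds 2 and 3, differing from compound 1 in several places, could not show. Nothing measured here explains the size of this step. Still open, from the compounds shown here alone, is how an amine, a carboxylic acid or a longer chain at this position would read. Going by these compounds, whether the same change holds on the core of compound 2 also remains open.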